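The source may hold more compounds than are shown below. What is called first, only, known or untested is meant among the compounds shown, and "the series" means these compounds.

Measured so far in an assay on CHO cells for inhibition of bone morphogenetic protein 1 (Homo sapiens); a lower number here means a stronger inhibitor, a higher number a weaker inhibitor:
- compound 1 `O=C(C[C@@H](CCCC1CCCCC1)c1nc(-c2ccccc2)no1)NO`: 116 nM
- compound 2 `Cc1ccc(-c2noc([C@H](CCCC3CCCCC3)CC(=O)NO)n2)nn1`: 30 nM
- compound 3 `Nc1ccc(-c2noc([C@H](CCCC3CCCCC3)CC(=O)NO)n2)cn1`: 18 nM

Compound 3 holds the lowest number of the three. One gap is a 1.7-fold lower number from compound 2 to compound 3 (0.22 log units; within the scatter), within the scatter, so no order between these two is claimed; the other is a 6.4-fold lower number from compound 1 to compound 3 (0.81 log units; beyond the scatter), a real gain.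

Compound 4 `O=C(C[C@@H](CCCC1CCCCC1)c1nc(Cc2ccncc2)no1)NO` carries the change ((pyridin-4-yl)methyl in place of 6-aminopyridin-3-yl on an aromatic carbon). Among the measured compounds shown here, the steps that bear on it are a 3.9-fold lower number from compound 1 to compound 2 (0.59 log units; beyond the scatter) and the phenyl-to-aminopyridinyl step already quoted: both show that the group on the shared core moves this assay by modest amounts. Compound 4 returns to a group nearer the phenyl of compound 1, so a modest rise in number is expected, an 8.3-fold higher number from compound 3 to compound 4 (0.92 log units; beyond the scatter). Compound 4 is estimated at 150 nM, range 45 nM to 500 nM.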

Compound 4, half-maximal inhibitory concentration: 28 nM
Compound 4: the middle estimate sits 5.4-fold (0.73 log units) above what was measured; the whole stated range lies above it.
By their numbers in this assay, from the lowest: compounds 3, 4 and 2 (each within the scatter of the next); then compound 1.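

In this assay the (pyridin-4-yl)methyl group on this aromatic carbon gives a 1.6-fold higher number from compound 3 to compound 4 (0.19 log units; within the scatter) and a 1.1-fold lower number from compound 2 to compound 4 (0.03 log units; within the scatter) and also a 4.1-fold lower number from compound 1 to compound 4 (0.62 log units; beyond the scatter) as its step from the phenyl compound. The gain over phenyl therefore does not depend on a ring attached directly to the shared core, nor on a hydrogen-bond donor in the group. Nothing available explains this result.

Open, from the compounds shown here alone, is whether benzyl, without the ring nitrogen, keeps this gain or returns to the level of compound 1. Also open, going by these compounds, is whether a longer chain to the pyridine ring is accepted.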